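Cyclopropyl for methyl on the sulfonyl of compound 1

The source may hold more compounds than are shown below. What is called first, only, known or untested is meant among the compounds shown, and "the series" means these compounds.

Measured so far:
compound 1 `CN1CCN(c2ccc(Nc3ncc4nc(Nc5ccccc5)n([C@H]5CCN(S(C)(=O)=O)C5)c4n3)cc2)CC1` gives 17 nM
compound 2 `CC(=O)Nc1cccc(-n2c(Nc3ccc(F)cc3)nc3cnc(Nc4ccc(N5CCN(C)CC5)cc4)nc32)c1` gives 10 nM
compound 3 `CN1CCN(c2ccc(Nc3ncc4nc(Nc5ccc(F)cc5)n([C@@H]5CCCNC5)c4n3)cc2)CC1` gives 120 nM

In a functional assay on HCC827 cells (Homo sapiens) for antiproliferative activity, read by MTT assay, with a stated time of 72 h (a lower number here means a stronger inhibitor, a higher number a weaker inhibitor), compound 1 stands second highest of the three numbers; its gap to compound 2 lies within the scatter, its gap to compound 3 beyond it. Within the data shown here, the only single-point step measured, a 12-fold higher number from compound 2 to compound 3 (1.08 log units; beyond the scatter), concerns piperidin-3-yl in place of 3-acetamidophenyl on an aromatic nitrogen, a different site from the one changed here, so it does not bear on the present step.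

Compound 4 `CN1CCN(c2ccc(Nc3ncc4nc(Nc5ccccc5)n([C@H]5CCN(S(=O)(=O)C6CC6)C5)c4n3)cc2)CC1` differs from compound 1 by cyclopropyl in place of methyl on a sulfonyl sulfur. Among the measured compounds shown here, no measured step touches the sulfonyl substituent, so no step beyond the scatter is expected; compound 4 is estimated at 17 nM (range 7 nM to 45 nM), meaning an expected step of no change at the digits printed from compound 1 to compound 4 (within the scatter).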

Compound 4, half-maximal inhibitory concentration: 1.6 nM
Beside the measured number, compound 4's estimate is 11-fold (1.03 log units) above it, and the stated range ends above it.
By their numbers in this assay, from the lowest: compound 4; then compounds 2 and 1 (each within the scatter of the next); then compound 3.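

In this assay, the substituent on the sulfonyl sulfur proves to be a sensitive position: cyclopropyl in place of methyl gives an 11-fold lower number from compound 1 to compound 4 (1.03 log units; beyond the scatter). Among these compounds, the earlier compounds held no change at this site, so this is the first sign that the series responds to it. Nothing available accounts for the size of this step.

As far as these compounds go, whether the gain belongs to the three-membered ring itself remains open, since an ethyl, isopropyl or cyclobutyl group on the sulfonyl sulfur would be needed to separate ring from chain and ring size.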